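Ester variation on a nitrophenyl amide series

The source may hold more compounds than are shown below. What is called first, only, known or untested is meant among the compounds shown, and "the series" means these compounds.

Measured so far in a functional assay on HepG2 cells (Homo sapiens) for inhibition, read by MTT assay, with a stated time of 72 h; a lower number here means a stronger inhibitor, a higher number a weaker inhibitor:
compound 1 `O=C(OC1(C(=O)Nc2ccc([N+](=O)[O-])cc2)CCCCC1)c1ccc(C(F)(F)F)cc1` gives 29.1 nM
compound 2 `O=C(/C=C/c1ccccc1)OC1(C(=O)Nc2ccc([N+](=O)[O-])cc2)CCCCC1` gives 52.9 nM
compound 3 `O=C(OC1(C(=O)Nc2ccc([N+](=O)[O-])cc2)CCCCC1)c1ccccc1` gives 734 nM

Compound 3 has the highest number of the three. Its steps to the others are both large: a 25-fold higher number from compound 1 to compound 3 (1.40 log units; beyond the scatter) and a 14-fold higher number from compound 2 to compound 3 (1.14 log units; beyond the scatter). Between compound 1 and compound 2 the step is small: a 1.8-fold higher number from compound 1 to compound 2 (0.26 log units; within the scatter). Across these three, the acyl part of the ester is the only thing that changes, and the one carrying a bare phenyl gives the weakest result.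

Compound 4 `CCC(=O)OC1(C(=O)Nc2ccc([N+](=O)[O-])cc2)CCCCC1` continues along the same ester position: ethyl in place of phenyl on a carbonyl carbon. Within the data shown here, no measured pair shows a ring removed from this carbonyl carbon, so nothing bears on the step directly. What is known is that each change seen so far at this acyl group moved this assay beyond the scatter when the group was made smaller or plainer, and that compound 3 already sits at the high end. The step to compound 4 is therefore expected to go upward, by a size comparable to those already seen, though with wide uncertainty.

The expected step is a 2.7-fold higher number from compound 3 to compound 4 (0.44 log units; beyond the scatter). Compound 4 is estimated at about 2000 nM, within 600 nM to 7000 nM.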

Compound 4, half-maximal inhibitory concentration: 21.5 nM
Beside the measured number, compound 4's estimate is 93-fold (1.97 log units) above it, and the stated range ends above it.
By their numbers in this assay, from the lowest: compounds 4, 1 and 2 (each within the scatter of the next, the first and the last beyond it); then compound 3.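

Ethyl in place of phenyl on a carbonyl carbon gives a 34-fold lower number from compound 3 to compound 4 (1.53 log units; beyond the scatter) in this assay and so shows that a ring on this carbonyl carbon is not needed for a low number; the earlier reading, in which a smaller or plainer acyl group moved the number upward, does not hold for compound 4. Against the larger acyl groups, the change to ethyl gives a 2.5-fold lower number from compound 2 to compound 4 (0.39 log units; beyond the scatter) as a modest step and a 1.4-fold lower number from compound 1 to compound 4 (0.13 log units; within the scatter) within the scatter, so compound 4 and compound 1 cannot be ordered, and size of the acyl group does not sort the four compounds, with compound 3 standing alone at the high end. Nothing measured here accounts for why the unsubstituted benzoyl ester of compound 3 differs so sharply from the propanoyl ester of compound 4.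

Still open, going by these compounds, is whether a shorter or longer chain, such as acetyl or hexanoyl, keeps the number as low as ethyl does. Also open, on these data alone, is whether groups other than trifluoromethyl on the phenyl of compound 3, such as a methoxy group or a chlorine, recover the low number that compound 1 shows.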